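Removing the acetyl from the ring nitrogen of compound 1

The source may hold more compounds than are shown below. What is called first, only, known or untested is meant among the compounds shown, and "the series" means these compounds.

Compound 1 `CC(=O)N1c2ccccc2CCC1C(=O)Nc1cc(C(F)(F)F)cc(C(F)(F)F)c1` is the starting point of this note. In a functional assay on MDA-MB-231 cells (Homo sapiens) for cytotoxicity, read by sulforhodamine B assay, with a stated time of 72 h (a lower number here means a stronger inhibitor of growth, a higher number a weaker inhibitor of growth), compound 1 reaches only the assay limit, > 70000 nM, so no number is known for it. the limit of > 70000 nM in this assay, at which 1 of the 3 values shown sits, marks where compound 1 stands: of the three values shown, only this one is a limit. Two further members of the series carry numbers. Compound 2 `O=C(Nc1ccccc1C(F)(F)F)C1CCc2ccccc2N1C(=O)c1ccccc1` gives 5290 nM in this assay. Compound 3 `O=C(Nc1ccccc1O)C1CCc2ccccc2N1`, which carries a free ring nitrogen, gives 5260 nM in this assay; these two values lie within the usual scatter of each other. Among the compounds with values here, no pair among the measured compounds differs in a single place, so no measured step is available.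

Compound 4 `O=C(Nc1cc(C(F)(F)F)cc(C(F)(F)F)c1)C1CCc2ccccc2N1` is not yet measured. It differs from compound 1 by hydrogen in place of acetyl on a nitrogen on an aromatic ring in a ring. Compound 3 shows that a member with a free ring nitrogen can give a number rather than a limit, 5260 nM. On that basis the expected step is an at least 5.8-fold lower number from compound 1 to compound 4 (0.76 log units; beyond the scatter), toward stronger growth inhibition, though a limit remains possible. Compound 4 is expected to give about 12000 nM, within 2500 nM to 60000 nM.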

Compound 4, concentration for 50% growth inhibition: 8270 nM
Beside the measured number, compound 4's estimate is 1.5-fold (0.16 log units) above it; the measured number falls inside the stated range.
By their numbers in this assay, from the lowest: compounds 3, 2 and 4 (each within the scatter of the next). At a limit, above all of these: compound 1.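

In this assay, within the data shown here, the step of an at least 8.4-fold lower number from compound 1 to compound 4 (0.92 log units; beyond the scatter) is the first measured change confined to one place: hydrogen in place of acetyl on the ring nitrogen, with the rest of the structure kept the same. The earlier compounds shown here differ from one another in more than one place, so they could not isolate this position, whereas this pair ties a change beyond the scatter to the acetyl on that nitrogen. The value for compound 1, > 70000 nM, is a limit of the assay, so the step has a lower bound but no known full size: the limit of > 70000 nM in this assay, at which 1 of the 4 values shown sits.

Going by these compounds, it remains open whether this reading is specific to acetyl or extends to other groups on the ring nitrogen of the core of compound 4, such as a methyl, a longer acyl chain like butanoyl, or a methanesulfonyl. Also open, on these data alone, is how a carboxylic acid or an amine on that nitrogen, reached through a short chain, would read in this assay.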